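The source may report more compounds than this note shows. Statements on the series, on what has been measured and on what is new or still open speak of the compounds shown alone.

Measured compounds in an assay on isolated protein for inhibition of histone deacetylase HD1B (Zea mays); a lower number here means a stronger inhibitor, a higher number a weaker inhibitor:
- compound 1, `Cn1cc(/C=C/C(=O)c2ccccc2Cl)cc1/C=C/C(=O)NO`, gives 1600 nM
- compound 2, `Cn1cc(/C=C/C(=O)c2ccc(Cl)cc2)cc1/C=C/C(=O)NO`, gives 29400 nM
- compound 3, `Cn1cc(/C=C/C(=O)c2ccccc2F)cc1/C=C/C(=O)NO`, gives 3400 nM

Compound 3 sits second highest of the three numbers, with compound 1 nearest and compound 2 furthest, as shown by a 2.1-fold higher number from compound 1 to compound 3 (0.33 log units; beyond the scatter) and an 8.6-fold lower number from compound 2 to compound 3 (0.94 log units; beyond the scatter). Compound 4 is `COc1cccc(C(=O)/C=C/c2cc(/C=C/C(=O)NO)n(C)c2)c1` and has not been measured in this assay.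

The change from compound 3 to compound 4: 3-methoxyphenyl in place of 2-fluorophenyl on a carbonyl carbon.

Within the data shown here, two measured steps bear on it. The shift of the substituent on the phenyl ring away from its position in compound 1 gave an 18-fold higher number from compound 1 to compound 2 (1.26 log units; beyond the scatter), a large weakening. The exchange of one halogen for another at a fixed position gave a 2.1-fold higher number from compound 1 to compound 3 (0.33 log units; beyond the scatter), a modest effect. Among the measured compounds shown here, the step to compound 4 both moves the substituent and replaces it, so the first of these is the more telling guide; no measured step covers a 3-methoxyphenyl or any methoxy group, so the exact size is uncertain.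

A weakening beyond the scatter is therefore expected, likely smaller than the step from compound 1 to compound 2 but clearly above the scatter; the expected step is a 3.5-fold higher number from compound 3 to compound 4 (0.55 log units; beyond the scatter). Compound 4 is estimated at 12000 nM, within a range of 3500 nM to 40000 nM.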

Compound 4, half-maximal inhibitory concentration: 600 nM
Compound 4: the middle estimate sits 20-fold (1.30 log units) above what was measured; measured number outside the range, below it.
By their numbers in this assay, from the lowest: compound 4; then compound 1; then compound 3; then compound 2.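

In this assay, 3-methoxyphenyl on the carbonyl carbon gives the strongest inhibitor of the four, with a 2.7-fold lower number from compound 1 to compound 4 (0.43 log units; beyond the scatter) and a 5.7-fold lower number from compound 3 to compound 4 (0.75 log units; beyond the scatter) showing that neither 2-chlorophenyl nor 2-fluorophenyl is needed for the best number in this set. The earlier compounds shown here held only halogen-bearing phenyl groups, and the weak 4-chlorophenyl of compound 2 left the 2-halophenyl groups as the only good ones, whereas a 49-fold lower number from compound 2 to compound 4 (1.69 log units; beyond the scatter) now shows how wide the spread at this one position can be. Compound 4 changes both the substituent and its place on the phenyl ring, so the gain cannot be assigned to the methoxy group or to the 3-position alone, and nothing on hand gives a reason for it.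

The compounds shown leave open how 3-chlorophenyl, 3-fluorophenyl, 2-methoxyphenyl and 4-methoxyphenyl would compare, and those four would separate the effect of the group from that of its place. Also open, from the compounds shown here alone, is whether a 3-aminophenyl, a 3-carboxyphenyl or a longer 3-ethoxyphenyl would hold or lower the number reached by compound 4.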